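The source may report more compounds than this note shows. Statements on the series, on what has been measured and on what is new or still open speak of the compounds shown alone.

The shared core carries two phenyl groups and a chain on an aromatic nitrogen. Compound 1 `CCCCn1nc(-c2ccccc2)c(-c2ccccc2)cc1=O` gives 176000 nM in an assay on microsomes from liver for inhibition of sterol O-acyltransferase 1 (Rattus norvegicus); on this read-out higher numbers stand for weaker inhibition and lower numbers for stronger inhibition. Compound 2 `CCCCCCCCCn1nc(-c2ccccc2)c(-c2ccccc2)cc1=O` gives 85000 nM, and the step of a 2.1-fold lower number from compound 1 to compound 2 (0.32 log units; beyond the scatter) lies beyond the scatter. Compound 3 `CCCCCCn1nc(-c2ccccc2)c(-c2ccccc2)c(C)c1=O` gives 56000 nM, a number that sits within the scatter of compound 2, so the two are not told apart here. Compound 2 therefore stands between the others on the numbers shown, separated only from compound 1.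

Compound 4 `O=C(O)CCCCCCn1nc(-c2ccccc2)c(-c2ccccc2)cc1=O` differs from compound 2 in one place: carboxy in place of propyl on a saturated chain carbon, six bonds along the chain from an aromatic nitrogen. Among the measured steps, only the one from compound 1 to compound 2 touches this chain at all, and it concerns the length of the chain rather than a carboxy group; its size was a 2.1-fold lower number from compound 1 to compound 2 (0.32 log units; beyond the scatter). Among the compounds with values here, no measured step shows what a carboxy group at the end of this chain does in this assay. Within the data shown here, with that one loosely related step as the only guide, compound 4 is expected to remain close to compound 2, with a step of a 1.2-fold higher number from compound 2 to compound 4 (0.07 log units; within the scatter) that is not expected to pass beyond the scatter in either direction. Compound 4 is thus estimated at 100000 nM, with a range from 40000 nM to 250000 nM.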

Compound 4, half-maximal inhibitory concentration: > 300000 nM
Compound 4: no number, only a limit; the forecaster's own chance of this, stated with the estimate: 20%; middle value at least 3.0-fold (0.47 log units) from the limit.
By their numbers in this assay, from the lowest: compounds 3 and 2 (each within the scatter of the next); then compound 1. At a limit, above all of these: compound 4.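

Placing a carboxy group where propyl stood changes the result in a direction that the one earlier step on this chain, a change of length, gave no sign of: in this assay the change gives an at least 3.5-fold higher number from compound 2 to compound 4 (0.54 log units; beyond the scatter), so what the chain carries, six bonds along from the aromatic nitrogen, is not a matter of indifference in this series. Measured against the shorter chain of compound 1, the carboxy-ended chain gives an at least 1.7-fold higher number from compound 1 to compound 4 (0.23 log units; that floor lies within the scatter), and as that floor lies within the scatter, this step alone does not tell the two compounds apart. Compound 4 has no number here, only a limit of the assay: the limit of > 300000 nM in this assay, at which 1 of the 4 values shown sits.

From the compounds shown here alone, only the floor of each step can be read, so their full sizes stay open. Also open, going by these compounds, is whether a methyl ester, a primary amide or an amine at the end of the chain would behave like the carboxy group, and whether a carboxylic acid on a shorter or longer chain would give the same result.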